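Replacing the Iodine of Compound 3 with a Longer Chain

The compounds below may be only part of what the source reports. "The series", "measured", "known", "first", "only" and "open" are said of these compounds alone.

Three compounds share one core. Compound 1 `O=c1[nH]/c(=N\OCCOc2ccccc2)ccn1[C@@H]1O[C@H](COP(=O)(O)OP(=O)(O)OP(=O)(O)O)[C@@H](O)[C@H]1O` gives 430 nM in a functional assay on 1321-N1 cells for agonist activity at P2Y purinoceptor 4 (Homo sapiens), read by scintillation counting and inositol phosphate accumulation; a higher number here means that more compound is needed for the effect, a lower number that less compound is needed. Compound 2 `O=c1[nH]/c(=N\OCCCc2cccc(I)c2)ccn1[C@@H]1O[C@H](COP(=O)(O)OP(=O)(O)OP(=O)(O)O)[C@@H](O)[C@H]1O` gives 114 nM in this assay, and compound 3 `O=c1[nH]/c(=N\OCCCc2ccc(I)cc2)ccn1[C@@H]1O[C@H](COP(=O)(O)OP(=O)(O)OP(=O)(O)O)[C@@H](O)[C@H]1O` gives 91 nM in this assay. Compound 3 holds the lowest of the three numbers, though its gap to compound 2 is within the scatter, while a 4.7-fold lower number from compound 1 to compound 3 (0.67 log units; beyond the scatter) lies beyond it. The unmeasured compound 4 `C#CCCNC(=O)COc1ccc(CCCO/N=c2/ccn([C@@H]3O[C@H](COP(=O)(O)OP(=O)(O)OP(=O)(O)O)[C@@H](O)[C@H]3O)c(=O)[nH]2)cc1` differs from compound 3 by a group of 9 heavy atoms (6 carbon, 1 nitrogen, 2 oxygen; no ring) in place of one iodine atom, on an aromatic carbon. For the measured compounds named here, no measured step swaps an iodine for such a group. The step of a 1.3-fold lower number from compound 2 to compound 3 (0.10 log units; within the scatter) shows that the iodine's position made no difference beyond the scatter, while a 3.8-fold lower number from compound 1 to compound 2 (0.58 log units; beyond the scatter) and a 4.7-fold lower number from compound 1 to compound 3 (0.67 log units; beyond the scatter) were modest. A small rise is therefore expected for compound 4, a 1.8-fold higher number from compound 3 to compound 4 (0.25 log units; within the scatter), giving an estimated 160 nM with a range from 60 nM to 450 nM.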

Compound 4, half-maximal effective concentration: 40 nM
Compound 4: middle estimate off by 4.0-fold (0.60 log units), on the high side; measured number below the stated range.
By their numbers in this assay, from the lowest: compound 4; then compounds 3 and 2 (each within the scatter of the next); then compound 1.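

The iodine is not required at this position: in this assay, a group of 9 heavy atoms with a triple bond replaces it, giving a 2.3-fold lower number from compound 3 to compound 4 (0.36 log units; beyond the scatter). The earlier compounds shown here only moved the iodine or changed the chain, so they could not show that this aromatic carbon accepts a much larger group without losing activity. No evidence is available to explain the drop.

Which part of the new group matters remains open, as does how an amine or a carboxylic acid on this carbon would compare.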